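The source may report more compounds than this note shows. Statements on the series, on what has been measured and on what is new or still open speak of the compounds shown alone.

Values in a functional assay on NCI/ADR-RES cells (Homo sapiens) for antiproliferative activity; on this read-out higher numbers stand for weaker inhibition of growth and lower numbers for stronger inhibition of growth:
- compound 1 `CC/C=C\[C@H](C)[C@H](OC(N)=O)[C@@H](C)[C@H](O)[C@@H](C)C/C(C)=C\[C@H](C)[C@@H](O)[C@@H](C)/C=C\[C@@H](O)C[C@H](O)[C@H](C)CO`: 10000 nM
- compound 2 `CC/C=C\[C@H](C)[C@H](OC(N)=O)[C@@H](C)[C@H](O)[C@@H](C)C/C(C)=C\[C@H](C)[C@@H](O)[C@@H](C)/C=C\[C@@H](O)C[C@@H]1OC(=O)[C@H](C)[C@@H](OC)[C@H]1C`: 250 nM

Of these two, compound 1 holds the higher number, 10000 nM, and so the weaker inhibition of growth. Compound 3 `CC/C=C\[C@H](C)[C@H](OC(N)=O)[C@@H](C)[C@H](O)[C@@H](C)C/C(C)=C\[C@H](C)[C@@H](O)[C@@H](C)/C=C\[C@H](O)C[C@@H]1CCC(=O)O1` is not yet measured. It departs from compound 1 as follows: a group of 9 heavy atoms (6 carbon, 3 oxygen; one five-membered non-aromatic ring with 1 hetero atom) in place of a group of 9 heavy atoms (6 carbon, 3 oxygen; no ring), on a double-bonded chain carbon bound to a double-bonded chain carbon.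

Among the measured compounds shown here, one measured step bears on this change: a 40-fold lower number from compound 1 to compound 2 (1.60 log units; beyond the scatter). That large step also puts a group with a ring, there six-membered and non-aromatic, in place of a group with no ring. For the measured compounds named here, the ring in compound 3 is five-membered, and no measured compound carries such a ring, so the size of the effect cannot be carried over directly. Going by the values given here, a step in the same direction is expected in this assay, towards a lower number, but probably a smaller one, with compound 2 at 250 nM as the only guide. The expected step is a 5.0-fold lower number from compound 1 to compound 3 (0.70 log units; beyond the scatter). For compound 3 the estimated value is 2000 nM, with an expected range from 400 nM to 10000 nM.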

Compound 3, concentration for 50% growth inhibition: 10000 nM
The estimate for compound 3 lay 5.0-fold (0.70 log units) below the measured number; measured number inside the range.
By their numbers in this assay, from the lowest: compound 2; then compounds 1 and 3 (each within the scatter of the next).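

In this assay, the five-membered non-aromatic ring with 1 hetero atom, on a double-bonded chain carbon bound to a double-bonded chain carbon, gives no change at the digits printed from compound 1 to compound 3 (within the scatter). A ring in place of the open group is therefore not sufficient on its own to lower the number in this series, although the group count stays at 9 heavy atoms (6 carbon, 3 oxygen) while hydrogen-bond donors go from 3 to 1 and defined stereocentres from 3 to 2. Of the two ring-bearing changes, only the six-membered one carries a step beyond the scatter, a 40-fold lower number from compound 1 to compound 2 (1.60 log units; beyond the scatter).

The compounds shown do not separate ring size from the methyl and methoxy groups on the six-membered ring, and a five-membered ring carrying those same methyl and methoxy groups would address that point directly. As far as these compounds go, it also remains open how this assay responds when this place carries an open-chain group ending in a carboxylic acid or an amine. Nothing available gives a reason for the result at compound 3.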